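The source may hold more compounds than are shown below. What is called first, only, known or untested is meant among the compounds shown, and "the series" means these compounds.

Of the compounds shown here, three built on a shared core have been measured so far. Compound 1 `COc1ccc(-c2nnc(SCCn3c([N+](=O)[O-])cnc3C)o2)cc1` gives 5800 nM in a functional assay on HepG2 cells (Homo sapiens) for cytotoxicity, read by MTT assay, with a stated time of 48 h; on this read-out higher numbers stand for weaker inhibition and lower numbers for stronger inhibition. Compound 2 `COc1ccc(-c2nnc(SCCn3c([N+](=O)[O-])cnc3C)o2)c(O)c1` gives 11000 nM in this assay, and compound 3 `COc1cc(-c2nnc(SCCn3c([N+](=O)[O-])cnc3C)o2)cc(OC)c1OC` gives 14900 nM. Compound 1 holds the smallest of the three numbers, but its distance to compound 2, a 1.9-fold higher number from compound 1 to compound 2 (0.28 log units; within the scatter), is within the scatter, and only compound 3 sits beyond the scatter from it.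

Compound 4 `Cc1ncc([N+](=O)[O-])n1CCSc1nnc(-c2cccs2)o1` has not yet been measured. It differs from compound 1 at one site, where (thiophen-2-yl in place of 4-methoxyphenyl on an aromatic carbon). Among the measured compounds shown here, no measured step covers this exchange: the single step in hand, a 1.9-fold higher number from compound 1 to compound 2 (0.28 log units; within the scatter), concerns a different position and was itself small. For the measured compounds named here, the record therefore gives no direct guide to the replacement of the 4-methoxyphenyl by the thiophen-2-yl, and the three numbers known span only a narrow band.

On that footing, compound 4 is expected to remain close to compound 1, with an estimated step of a 1.2-fold higher number from compound 1 to compound 4 (0.08 log units; within the scatter), not beyond the scatter. Compound 4 is estimated at 7000 nM, with a range from 3000 nM to 16000 nM.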

Compound 4, half-maximal inhibitory concentration: 20500 nM
For compound 4 the middle estimate is 2.9-fold (0.47 log units) below the measured one, and the stated range ends below it.
By their numbers in this assay, from the lowest: compounds 1, 2, 3 and 4 (each within the scatter of the next, the first and the last beyond it).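

At the aromatic carbon next to the ring nitrogen and the ring oxygen, replacing the 4-methoxyphenyl of compound 1 with thiophen-2-yl gives a 3.5-fold higher number from compound 1 to compound 4 (0.55 log units; beyond the scatter) in this assay and thus shows that this exchange can move the read-out towards weaker inhibition. The earlier step of a 1.9-fold higher number from compound 1 to compound 2 (0.28 log units; within the scatter) had stayed within the scatter and concerned a hydroxy group in place of hydrogen, so it gave no such sign for a change of the whole aromatic group. Here a six-membered aromatic ring of carbon only gives way to a five-membered aromatic ring with one hetero atom, the entering group has fewer heavy atoms, and the counts of hydrogen-bond donors and acceptors stay the same, but no measurement at hand accounts for the step.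

The compounds shown do not separate the loss of the methoxy group from the change of ring, and a plain phenyl or a furan-2-yl at this place would be needed to tell the two apart. Also open, from the compounds shown here alone, is whether an amine or a carboxylic acid on the aromatic group would shift the read-out in either direction.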